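Chromone triazoles on gastric cancer cells: a fluoro analogue

The compounds below may be only part of what the source reports. "The series", "measured", "known", "first", "only" and "open" are said of these compounds alone.

Of the compounds shown here, three sharing one core have been tested in a functional assay on SGC-7901 cells (Homo sapiens) for cytotoxicity, read by MTT assay, with a stated time of 48 h; on this read-out lower numbers stand for stronger inhibition and higher numbers for weaker inhibition. Compound 1 `O=c1ccoc2cc(OCc3cn(Cc4cccc(F)c4)nn3)ccc12` gives > 100000 nM, which is a limit of the assay. Compound 2 `O=c1ccoc2cc(OCc3cn(Cc4cccc(Cl)c4)nn3)ccc12` gives > 100000 nM, again a limit. Compound 3 `O=c1ccoc2cc(OCc3cn(Cc4ccccc4Cl)nn3)ccc12` gives > 100000 nM, also a limit. Compound 2 and compound 3 have the same atoms joined differently, as described in 2-chlorophenyl in place of 3-chlorophenyl on a saturated chain carbon bound to an aromatic nitrogen. Compound 1 differs from compound 2 by fluoro in place of chloro on an aromatic carbon, and the step that the two limits leave unreadable from compound 2 to compound 1 cannot be read because the limit of > 100000 nM in this assay, at which 3 of the 3 values shown sit, covers all three values.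

Compound 4 `O=c1ccoc2cc(OCc3cn(Cc4ccccc4F)nn3)ccc12` has not been measured. It differs from compound 3 by fluoro in place of chloro on an aromatic carbon, the same kind of change as from compound 2 to compound 1, but here the place is ortho to a large group rather than meta to a large group. Because the limit of > 100000 nM in this assay, at which 3 of the 3 values shown sit, holds every value shown, compound 4 is expected to behave like compound 3, and its step that the limit leaves unreadable from compound 3 to compound 4 is estimated to be negligible. In this assay compound 4 is expected to give 150000 nM, between 100000 nM and 400000 nM.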

Compound 4, half-maximal inhibitory concentration: > 100000 nM
Compound 4: a limit, no number (the forecaster's own chance of this, stated with the estimate: 85%); the middle value does not contradict the limit.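

No step from compound 1, compound 2 or compound 3 to compound 4 can be read, because none of these results gives a number to compare: the limit of > 100000 nM in this assay, at which 4 of the 4 values shown sit.

The compounds shown leave open whether fluoro or chloro, or the place of either group, changes the result at all, and whether this shared core can reach a measurable value in this assay.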